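Compound 2 to compound 3: changing the chlorophenyl

A few compounds are considered here, and "the series" means these few. Any claim that something is new, unique, unknown or untested is made for them only; others in the source may bear on it.

Within the data shown here, in a functional assay on A549 cells (Homo sapiens) for antiproliferative activity, read by MTT assay, with a stated time of 72 h (a higher number here means a weaker inhibitor, a lower number a stronger inhibitor), compound 1 (`NC1=NC2(CCSCC2)N(OCCCOc2cccc(Cl)c2)C(N)=N1`) gives 60 nM and compound 2 (`NC1=NC2(CCSCC2)N(OCCCOc2cccc(Cl)c2Cl)C(N)=N1`) gives 1 nM, the lower of the two numbers so far. Compound 3 (`NC1=NC2(CCSCC2)N(OCCCOc2cc(Cl)c(Cl)cc2Cl)C(N)=N1`) has 2,4,5-trichlorophenyl in place of 2,3-dichlorophenyl on an oxygen on a saturated carbon. Among the measured compounds shown here, one measured step bears on this change: a 60-fold lower number from compound 1 to compound 2 (1.78 log units; beyond the scatter), a large step beyond the scatter that came with one added chloro. For the measured compounds named here, it is only a partial guide, since compound 3 differs from compound 2 in the whole chlorine pattern, and no measured compound carries the entering group. A further large drop in this assay is not expected from compound 2 at 1 nM. The expected change is small, at most a slight rise and none beyond the scatter, with an estimated 2.0-fold higher number from compound 2 to compound 3 (0.30 log units; within the scatter). The estimate for compound 3 is 2 nM, with an expected range of 0.4 nM to 15 nM.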

Compound 3, half-maximal inhibitory concentration: > 100000 nM
Compound 3: only a limit was reported (the forecaster's own chance of this, stated with the estimate: 5%); middle value at least 50000-fold (4.69 log units) from the limit.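

For compound 3 in this assay, only a limit was reported, not a number: the limit of > 100000 nM in this assay, at which 1 of the 3 values shown sits.

Read against that limit, the result is an at least 100000-fold higher number from compound 2 to compound 3 (5.00 log units; beyond the scatter) and an at least 1600-fold higher number from compound 1 to compound 3 (3.22 log units; beyond the scatter), so the change on this oxygen on a saturated carbon can take the series from its lowest number to its limit. Chlorine count alone therefore does not order the series: the added chloro lowered the number in a 60-fold lower number from compound 1 to compound 2 (1.78 log units; beyond the scatter), but compound 3, with the most chlorine, goes against that trend.

Compound 3 differs from compound 2 in both the number of chlorines and their pattern, and the compounds shown do not separate the two. Going by these compounds, how a 3,4-dichlorophenyl, a 2,4-dichlorophenyl or a methoxyphenyl would read on this oxygen also stays open.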